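Changing the Acid-Bearing Ring at the Far End

The source may hold more compounds than are shown below. What is called first, only, known or untested is meant among the compounds shown, and "the series" means these compounds.

Compound 1 `CCC(=O)c1ccc(OCCCCOc2ccc(F)c(C(=O)O)c2)c(C)c1O` and compound 2 `Cc1c(OCCCCOc2ccc(F)c(C(=O)O)c2)ccc(C(=O)CC2CCCC2)c1O` share one core and differ only at the saturated chain carbon bound to a carbonyl carbon. In an assay on HEK293 cells for positive allosteric modulation of metabotropic glutamate receptor 2 (Rattus norvegicus), read by thallium flux, with a stated time of 2.5 min (a higher number here means that more compound is needed for the effect, a lower number that less compound is needed), compound 1 gives 124 nM, while compound 2 gives 699 nM; the step of a 5.6-fold higher number from compound 1 to compound 2 (0.75 log units; beyond the scatter) arose from cyclopentyl in place of methyl at that carbon. Compound 2 therefore holds the highest of the two numbers recorded, with compound 1 as its nearest neighbour. Compound 3 `COC(=O)c1ccc(OCCCCOc2ccc(C(=O)CC3CCCC3)c(C)c2C)cc1` was also prepared, but in this assay compound 3 gives "not determined" (no result reported), so no number is available for it.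

Compound 4 `Cc1cc(OCCCCOc2ccc(C(=O)CC3CCCC3)c(O)c2C)ccc1C(=O)O` keeps the cyclopentyl of compound 2 and changes the other end of the molecule: 4-carboxy-3-methylphenyl in place of 3-carboxy-4-fluorophenyl on an oxygen on a saturated carbon. Among the measured compounds shown here, no measured step touches this end; the only measured step sits at the chain carbon, and compound 3, which differs at this end too, has no number. With nothing to lean on, a change beyond the scatter is not expected in either direction. Compound 4 is accordingly estimated at 700 nM, within a range from 200 nM to 2500 nM. The step expected is a 1.0-fold higher number from compound 2 to compound 4 (0.00 log units; within the scatter), a small one.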

Compound 4, half-maximal effective concentration: 564 nM
Beside the measured number, compound 4's estimate is 1.2-fold (0.09 log units) above it; low and high end bracket the measured number.
By their numbers in this assay, from the lowest: compound 1; then compounds 4 and 2 (each within the scatter of the next).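

In this assay, exchanging 3-carboxy-4-fluorophenyl for 4-carboxy-3-methylphenyl on an oxygen on a saturated carbon gives a 1.2-fold lower number from compound 2 to compound 4 (0.09 log units; within the scatter). Among the compounds shown here, this is the first measured change at this end of the molecule, and it shows that, with the cyclopentyl kept in place, one acid-bearing ring can replace the other without a change beyond the scatter. No separate measurement bears on why the two rings give such similar numbers.

As far as these compounds go, it remains open whether the same exchange would behave alike with the methyl of compound 1 in place of the cyclopentyl. Also open, from the compounds shown here alone, is what would happen if an amide or a tetrazole stood in place of the carboxylic acid on either ring, since a single exchange says little about other groups at this end.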